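Fluorine on the Sulfonyl Aryl: Compound 2 to Compound 4

This account rests on a few compounds, and the source may have more. Where it says the series, first, only, none or still open, it means among the compounds named here.

Three sulfonamides sharing one core have been tested in an assay on cells for inhibition of HSP60/HSP10 (Homo sapiens), with a stated time of 60 min; a lower number here means a stronger inhibitor, a higher number a weaker inhibitor. Compound 1 `O=S(=O)(Nc1ccc2oc(-c3ccccc3)nc2c1)c1ccc(Cl)c(Cl)c1` returns only a limit, > 100000 nM. Compound 2 `Cc1cccc(S(=O)(=O)Nc2ccc(-c3nc4ccccc4o3)cc2)c1` also returns only a limit, > 100000 nM, so among the numbers shown it stands as a limit and not as a measured value. Compound 3 `O=S(=O)(Nc1ccc(-c2nc3ccccc3o2)cc1)c1cccc(C(F)(F)F)c1` gives 57000 nM in this assay. For the measured compounds named here, the single step measured between neighbours, an at least 1.7-fold lower number from compound 2 to compound 3 (0.24 log units; that floor lies within the scatter), starts from a limit and its floor lies within the scatter, so it carries little information about the size of any change; indeed the limit of > 100000 nM in this assay, at which 2 of the 3 values shown sit, holds for two of the three values.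

Compound 4 `O=S(=O)(Nc1ccc(-c2nc3ccccc3o2)cc1)c1ccccc1F` differs from compound 2 by 2-fluorophenyl in place of 3-methylphenyl on a sulfonyl sulfur. Going by the values given here, no measured step concerns this exchange on the sulfonyl sulfur; the only step on record, an at least 1.7-fold lower number from compound 2 to compound 3 (0.24 log units; that floor lies within the scatter), touches a different substituent. Among the compounds with values here, with compound 2 at a limit and no informative step, no movement beyond the scatter is expected. Compound 4 is therefore estimated at 100000 nM, in the range 40000 nM to 300000 nM, most likely reported again as a limit. The expected step of a number no higher from compound 2 to compound 4 (the limit leaves the size open) lies within the scatter.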

Compound 4, half-maximal inhibitory concentration: > 100000 nM
Compound 4: only a limit was reported (the forecaster's own chance of this, stated with the estimate: 60%); the middle value sits exactly at the limit.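

Compound 2 and compound 4 both stand only at limits in this assay, so the step between them cannot be read. The compounds shown leave open whether 2-fluorophenyl in place of 3-methylphenyl on a sulfonyl sulfur moves the number at all, with most values resting on one boundary: the limit of > 100000 nM in this assay, at which 3 of the 4 values shown sit.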